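The source may hold more compounds than are shown below. What is called first, only, known or untested is meant among the compounds shown, and "the series" means these compounds.

Series notes, all in a functional assay on MCF7 cells (Homo sapiens) for antiproliferative activity, read by sulforhodamine B assay, with a stated time of 72 h; a lower number here means a stronger inhibitor, a higher number a weaker inhibitor.

Two compounds are measured. Compound 1 `Cc1ccc(COc2ccc(-c3cc(CN4CCN(Cc5ccc(C(F)(F)F)cc5)CC4)no3)cc2)cc1` gives 1200 nM in this assay. Among the measured compounds shown here, compound 2 `N#Cc1ccc(COc2ccc(-c3cc(CN4CCN(Cc5ccc(C(F)(F)F)cc5)CC4)no3)cc2)cc1` gives 100 nM in this assay, the lowest of the two numbers so far; its nearest neighbour is compound 1, and the single measured step, a 12-fold lower number from compound 1 to compound 2 (1.08 log units; beyond the scatter), separates them.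

Compound 3 `COc1cc(COc2ccc(-c3cc(CN4CCN(Cc5ccc(C(F)(F)F)cc5)CC4)no3)cc2)cc(OC)c1` is not yet measured. It differs from compound 2 by 3,5-dimethoxyphenyl in place of 4-cyanophenyl on a saturated chain carbon bound to an oxygen on an aromatic ring. For the measured compounds named here, the one measured step that bears on this change is a 12-fold lower number from compound 1 to compound 2 (1.08 log units; beyond the scatter), which shows what happens when the cyano on that aromatic ring is exchanged for methyl: a large rise in number. Compound 3 likewise gives up the cyano, but what enters is 3,5-dimethoxyphenyl rather than the methyl-bearing ring of compound 1, so that step is only an indirect guide. Since compound 2 owes its low number to the cyano as far as a 12-fold lower number from compound 1 to compound 2 (1.08 log units; beyond the scatter) shows, the expectation for compound 3 is a step of a 6.0-fold higher number from compound 2 to compound 3 (0.78 log units; beyond the scatter), toward the region of compound 1, with wide uncertainty. Compound 3 is therefore estimated at 600 nM, with a range of 150 nM to 2500 nM.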

Compound 3, half-maximal inhibitory concentration: 100 nM
Compound 3: the middle estimate sits 6.0-fold (0.78 log units) above what was measured; the measured number lies below the stated range.
By their numbers in this assay, from the lowest: compounds 2 and 3 (each within the scatter of the next); then compound 1.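

In this assay, 3,5-dimethoxyphenyl in place of 4-cyanophenyl on a saturated chain carbon bound to an oxygen on an aromatic ring gives no change at the digits printed from compound 2 to compound 3 (within the scatter), so among these compounds a nitrile is not needed for a number at this level. The same ring against 4-methylphenyl gives a 12-fold lower number from compound 1 to compound 3 (1.08 log units; beyond the scatter), a step that matches a 12-fold lower number from compound 1 to compound 2 (1.08 log units; beyond the scatter) in size, leaving compound 1 alone at the higher number and showing that this position tolerates two quite different groups, one with a nitrile and one with two methoxy groups. No measurement available here accounts for why these two groups stand together or why 4-methylphenyl stands apart.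

The compounds shown leave open whether both methoxy groups of compound 3 are needed, which a ring with a single methoxy group or a plain phenyl ring would test. They also leave open how a pyridine ring, a carboxylic acid or an amine at this position would read, and whether the match between compound 2 and compound 3 holds when the rest of the shared core changes.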